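Stereochemical inversion on the ring: compound 3 to compound 4

The source may report more compounds than this note shows. Statements on the series, on what has been measured and on what is new or still open speak of the compounds shown alone.

Measured compounds:
Compound 1 `C[C@]1(O)C[C@@](c2cccc(C(F)(F)F)c2)([C@H](O)c2ccccn2)C1`: 150 mL/min/kg
Compound 2 `OC(c1ccccn1)C1(c2ccc(Cl)c(Cl)c2)CCOC1`: 417 mL/min/kg
Compound 3 `C[C@]1(O)C[C@@](c2cc(C(F)(F)F)ccn2)([C@H](O)c2ccccn2)C1`: 33.3 mL/min/kg

In an ADME assay on liver for metabolic stability, with Liver microsome (Homo sapiens) as the target, read by LC-MS, using microsomes, with a stated time of 5 h (on this read-out lower numbers stand for slow clearance and higher numbers for fast clearance), compound 3 gives 33.3 mL/min/kg, the lowest of the three numbers. Compound 1 stands nearest, its number higher by a gap beyond the scatter, and compound 2 stands furthest, higher by a gap also beyond the scatter. Compound 4 `C[C@]1(O)C[C@](c2cc(C(F)(F)F)ccn2)([C@H](O)c2ccccn2)C1` has not yet been measured. It differs from compound 3 only in drawn configuration: the two compounds have the same atoms and bonds and differ only in configuration as drawn: 2 of 3 stereo elements differ; a stereocentre at a saturated ring carbon is drawn R in compound 3 and S in compound 4; a stereocentre at a saturated ring carbon is drawn s in compound 3 and r in compound 4. Going by the values given here, no measured pair in the set shares this kind of change, so no measured step guides the expectation. A change of configuration alone is expected to shift clearance modestly, with direction uncertain, so the expected step of a 1.5-fold higher number from compound 3 to compound 4 (0.18 log units; within the scatter) is taken as close to the scatter. Compound 4 is therefore expected to give 50 mL/min/kg, within a range from 20 mL/min/kg to 130 mL/min/kg.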

Compound 4, clearance: 33.3 mL/min/kg
Compound 4: middle estimate off by 1.5-fold (0.18 log units), on the high side; measured number inside the range.
By their numbers in this assay, from the lowest: compounds 3 and 4 (each within the scatter of the next); then compound 1; then compound 2.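

Going by these compounds alone, the first comparison in one place, in this assay, reads no change at the digits printed from compound 3 to compound 4 (within the scatter). For this pair, clearance does not separate the two drawn ring configurations, so the configuration at these two ring stereocentres shows no measurable link to clearance here. This reading rests on a single pair: the fact that compounds 3 and 4 differ only in the configuration as drawn

On these data alone, whether the result holds for the aryl group of compound 1, or for a change at the remaining stereo element, stays open. Also open, as far as these compounds go, is how clearance would respond to an amine or a carboxylic acid in place of the trifluoromethyl group.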